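Second methoxy on the pendant aryl of compound 2

A few compounds are considered here, and "the series" means these few. Any claim that something is new, unique, unknown or untested is made for them only; others in the source may bear on it.

Measured so far:
compound 1 `COc1cc2c(Oc3ccc(NC(=O)c4cc(-c5ccc(C(F)(F)F)cc5)ccn4)cc3F)ccnc2cc1OCCCN1CCCC1`, 720 nM
compound 2 `COc1ccc(-c2ccnc(C(=O)Nc3ccc(Oc4ccnc5cc(OCCCN6CCCC6)c(OC)cc45)c(F)c3)c2)cc1`, 350 nM

In a functional assay on HT-29 cells (Homo sapiens) for cytotoxicity, read by MTT assay, with a stated time of 72 h (on this read-out higher numbers stand for weaker inhibition and lower numbers for stronger inhibition), compound 2 stands lowest of the two numbers, its nearest neighbour being compound 1. Among the measured compounds shown here, the one measured step, a 2.1-fold lower number from compound 1 to compound 2 (0.31 log units; beyond the scatter), concerns the substituent on the pendant aryl of the shared core.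

Compound 3 `COc1ccc(-c2ccnc(C(=O)Nc3ccc(Oc4ccnc5cc(OCCCN6CCCC6)c(OC)cc45)c(F)c3)c2)c(OC)c1` is not yet measured. It differs from compound 2 by methoxy in place of hydrogen on an aromatic carbon. For the measured compounds named here, no measured step touches this position: the step from compound 1 to compound 2 exchanged a group at a different carbon of the same ring, so it says nothing direct about a further methoxy ortho to a large group. Going by the values given here, with no guiding step, the expectation is a change within the scatter, with a slight risk of a higher number.

Compound 3 is therefore expected to give 420 nM (range 150 nM to 1300 nM), an expected step of a 1.2-fold higher number from compound 2 to compound 3 (0.08 log units; within the scatter).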

Compound 3, half-maximal inhibitory concentration: 630 nM
The estimate for compound 3 lay 1.5-fold (0.18 log units) below the measured number, within the range that was stated.
By their numbers in this assay, from the lowest: compounds 2, 3 and 1 (each within the scatter of the next, the first and the last beyond it).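

In this assay, among the compounds shown here, adding methoxy on the aromatic carbon ortho to a large group gives a 1.8-fold higher number from compound 2 to compound 3 (0.26 log units; within the scatter), so the change from 4-methoxyphenyl to 2,4-dimethoxyphenyl is the first reading at this position and stays within the scatter. Putting 2,4-dimethoxyphenyl in place of 4-(trifluoromethyl)phenyl gives a 1.1-fold lower number from compound 1 to compound 3 (0.06 log units; within the scatter), whereas the single methoxy gave a 2.1-fold lower number from compound 1 to compound 2 (0.31 log units; beyond the scatter), so the separation from compound 1 is seen for compound 2 only. Nothing at hand gives a reason for these readings.

On these data alone, still open in this assay is whether a group other than methoxy on this same carbon, such as fluorine, a hydroxy group or a dimethylamino group, would give a step beyond the scatter from compound 2. Also open, as far as these compounds go, is how a carboxylic acid or a primary amine on the pendant aryl would read.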